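A Formyl Chain End in Place of the Ester

This account rests on a few compounds, and the source may have more. Where it says the series, first, only, none or still open, it means among the compounds named here.

Compound 1 `COCCCCCCCCCCC/C=C1\CC(CO)(COC(=O)C(C)(C)C)OC1=O`: 0.701 ug/mL
Compound 2 `COC(=O)CCCCCCCCCCCCCC/C=C1\CC(CO)(COC(=O)C(C)(C)C)OC1=O`: 0.691 ug/mL

Both compounds were tested in a functional assay on CCRF-CEM cells (Homo sapiens) for antiproliferative activity; on this read-out lower numbers stand for stronger inhibition of growth and higher numbers for weaker inhibition of growth. Compound 2, at 0.691 ug/mL, cannot be told apart from compound 1, since the two values lie within the scatter of each other. The next compound, compound 3 `CC(C)(C)C(=O)OCC1(CO)C/C(=C\CCCCCCCCCCCCCCC=O)C(=O)O1`, departs from compound 2 at the end of the chain: hydrogen in place of methoxy on a carbonyl carbon. Hydrogen in place of methoxy on a carbonyl carbon turns methoxycarbonyl into formyl. Within the data shown here, only one measured step bears on this chain, a 1.0-fold lower number from compound 1 to compound 2 (0.01 log units; within the scatter), and it stays within the scatter. Among the measured compounds shown here, no measured step makes this exact exchange, so the evidence is thin. The expected change is a 1.0-fold higher number from compound 2 to compound 3 (0.01 log units; within the scatter), which means no shift beyond the scatter in either direction. For compound 3 the estimated value is 0.7 ug/mL, with an expected range of 0.28 ug/mL to 1.8 ug/mL.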

Compound 3, concentration for 50% growth inhibition: 0.933 ug/mL
The estimate for compound 3 lay 1.3-fold (0.12 log units) below the measured number; the range from low to high includes it.
By their numbers in this assay, from the lowest: compounds 2, 1 and 3 (each within the scatter of the next).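

In this assay, among these compounds, the exchange of methoxycarbonyl for formyl at the chain end gives a 1.4-fold higher number from compound 2 to compound 3 (0.13 log units; within the scatter) and so adds a first direct reading at this carbonyl carbon: losing the methoxy leaves no shift that can be told from the scatter. Measured against the methoxy chain end, the formyl chain gives a 1.3-fold higher number from compound 1 to compound 3 (0.12 log units; within the scatter) and so also stays within the scatter, which means that methoxy, methoxycarbonyl and formyl chain ends have now been read without any separation among the three. Nothing available explains this lack of separation.

As far as these compounds go, whether a carboxylic acid or an amine at the end of the chain would also stay within the scatter remains open. The compounds shown also leave open what a much shorter chain would do, since every chain end here sits on a long saturated chain.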